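Swapping a Butyl Chain for a Cyclobutyl Ring

A few compounds are considered here, and "the series" means these few. Any claim that something is new, unique, unknown or untested is made for them only; others in the source may bear on it.

Measured so far:
compound 1, `CCCCn1nc(C(=O)N[C@H]2COc3ccccc3N(C)C2=S)nc1Cc1ccccc1`, in a toxicity assay on HT-29 cells (Homo sapiens) for cytotoxicity; on this read-out higher numbers stand for lower toxicity in this test and lower numbers for higher toxicity in this test: > 100000 nM
compound 2, `CC(C)Cn1nc(C(=O)N[C@H]2COc3ccccc3N(C)C2=S)nc1Cc1ccccc1`, in this assay: > 100000 nM

Compound 1 gives > 100000 nM in this assay, which is a limit of the assay and not a number. Compound 2 likewise sits at a limit, > 100000 nM. Both values rest at the limit of > 100000 nM in this assay, at which 2 of the 2 values shown sit, so the step that the two limits leave unreadable from compound 1 to compound 2 cannot be read. Compound 3 `CN1C(=S)[C@@H](NC(=O)c2nc(Cc3ccccc3)n(C3CCC3)n2)COc2ccccc21` differs from compound 1 by cyclobutyl in place of butyl on an aromatic nitrogen. Among the compounds with values here, no measured step is readable, so no size of change can be drawn from the data. Compound 3 is therefore expected to remain at the limit, estimated at 150000 nM with a range of 50000 nM to 500000 nM. The step that the limit leaves unreadable from compound 1 to compound 3 is expected to be unreadable as well.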

Compound 3, half-maximal cytotoxic concentration: > 100000 nM
Compound 3: a limit, no number; the forecaster's own chance of this, stated with the estimate: 85%; the middle value is on the limit's open side.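

Within the data shown here, compound 3 also rests at a limit, so no step among compound 1, compound 2 and compound 3 can be read: the limit of > 100000 nM in this assay, at which 3 of the 3 values shown sit. The compounds shown leave open whether any group on the aromatic nitrogen would give a measurable value in this assay.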